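Changing the Aryl Group of Compound 2

The source may report more compounds than this note shows. Statements on the series, on what has been measured and on what is new or still open speak of the compounds shown alone.

Compound 1 `O=C(O)CC1COc2cc(OCc3csc(-c4ccccc4)n3)ccc21`: 0.15%
Compound 2 `Cc1ccccc1-c1nc(C)c(COc2ccc3c(c2)OCC3CC(=O)O)s1`: 10.7%

Of the compounds shown here, two have been measured in a functional assay on CHO cells for agonist activity at Free fatty acid receptor 1 (Homo sapiens), read by FLIPR and calcium flux, tested at 100 nM; a lower number here means a weaker effect, a higher number a stronger effect of the compound at the concentration tested. Compound 1 gives 0.15%, while compound 2 gives 10.7%. Compound 2 stands highest of the two, and its nearest neighbour, compound 1, lies lower by a gap beyond the scatter. Compound 3 `Cc1nc(-c2cccc(F)c2)sc1COc1ccc2c(c1)OCC2CC(=O)O` has not yet been measured and differs from compound 2 in one place: 3-fluorophenyl in place of 2-methylphenyl on an aromatic carbon. Among the compounds with values here, no measured pair shows this change, so only a small step is expected, in either direction, probably none beyond the scatter. Compound 3 is thus estimated to give 8% in this assay, within 0% to 25%. The expected step is a number 2.7 percentage points lower from compound 2 to compound 3 (within the scatter).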

Compound 3, a percentage reported as activity, at one concentration (the size of the read-out at that concentration, not a potency): 56.9%
Compound 3: the middle estimate sits 48.9 percentage points below what was measured; measured number outside the range, above it.
By their numbers in this assay, from the lowest: compound 1; then compound 2; then compound 3.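

The aryl group on the aromatic carbon next to the ring nitrogen and next to the ring sulfur proves decisive in this assay: 3-fluorophenyl in place of 2-methylphenyl gives a number 46.2 percentage points higher from compound 2 to compound 3 (beyond the scatter). The two groups match in heavy-atom count and in their absence of hydrogen-bond donors and acceptors, so this position responds to a difference those counts do not capture. Nothing available accounts for the step. As far as these compounds go, it remains open whether the gain follows the fluorine or the loss of the methyl group, and how a 3-chlorophenyl or 3-methoxyphenyl group would read at this place.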